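Trimming the ethoxy group from compound 3

The source may hold more compounds than are shown below. What is called first, only, known or untested is meant among the compounds shown, and "the series" means these compounds.

Measured compounds:
- compound 1 `O=C1NC(=O)/C(=C/c2ccc(OCN3C(=O)c4ccccc4C3=O)cc2)S1`: 25600 nM
- compound 2 `COc1cc(/C=C2\SC(=S)NC2=O)ccc1OCN1C(=O)c2ccccc2C1=O`: 16100 nM
- compound 3 `CCOc1cc(/C=C2\SC(=S)NC2=O)ccc1OCN1C(=O)c2ccccc2C1=O`: 7720 nM

All three were tested in an assay on isolated protein for inhibition of Alpha glucosidase (Homo sapiens), read by spectrophotometry, with stated times of 15 min and 30 min; a higher number here means a weaker inhibitor, a lower number a stronger inhibitor. Compound 3 gives the lowest number of the three, so within this set it is the strongest inhibitor; its nearest neighbour is compound 2, and compound 1 lies furthest away. Compound 4 `O=C1NC(=S)S/C1=C\c1ccc(OCN2C(=O)c3ccccc3C2=O)cc1` has not yet been measured. Compared with compound 3 the change is hydrogen in place of ethoxy on an aromatic carbon, so the ethoxy group is removed and only the shared core with its bare aromatic ring remains.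

Among the measured compounds shown here, only one measured step touches this region: a 2.1-fold lower number from compound 2 to compound 3 (0.32 log units; beyond the scatter), where lengthening methoxy to ethoxy helped. Going the other way, to no alkoxy group at all, is a larger change in the same direction than that step reversed, so a weaker inhibitor is expected. Compound 1, which also lacks any substituent on that ring but carries a different core, gives a high number, which points the same way, though it is not a single-change comparison with compound 4. The expected step is therefore a 2.8-fold higher number from compound 3 to compound 4 (0.45 log units; beyond the scatter). For compound 4 the estimate is 22000 nM, with a plausible range from 10000 nM to 50000 nM.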

Compound 4, half-maximal inhibitory concentration: 7910 nM
Compound 4: the middle estimate sits 2.8-fold (0.44 log units) above what was measured; the measured number lies below the stated range.
By their numbers in this assay, from the lowest: compounds 3 and 4 (each within the scatter of the next); then compounds 2 and 1 (each within the scatter of the next).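

In this assay, putting hydrogen in place of ethoxy on this aromatic carbon gives a 1.0-fold higher number from compound 3 to compound 4 (0.01 log units; within the scatter), so among these compounds an alkoxy group at this position is not required for this level of inhibition. The earlier methoxy-to-ethoxy step suggested that a longer chain helps, but hydrogen in place of methoxy gives a 2.0-fold lower number from compound 2 to compound 4 (0.31 log units; beyond the scatter), so the numbers do not follow chain length: the methoxy compound is the one that sits apart, while the compounds with hydrogen and ethoxy cannot be told apart. With this aromatic position bare in both compounds, the difference between the two cores also counts, as exchanging the core of compound 1 for that of compound 4 gives a 3.2-fold lower number from compound 1 to compound 4 (0.51 log units; beyond the scatter).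

No measurement available here explains why methoxy differs from both hydrogen and ethoxy. Going by these compounds, it remains open whether a longer chain such as propoxy, or a hydroxyl or an amine on this aromatic carbon, would separate from hydrogen, and whether an ethoxy group would behave the same way on the core of compound 1.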